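Amide heteroaryl swap: pyridine to methylimidazole on compound 2

The source may hold more compounds than are shown below. What is called first, only, known or untested is meant among the compounds shown, and "the series" means these compounds.

Compound 1 `COc1cc(F)c(NC(=O)c2ccncc2)cc1Nc1nccc(-c2cn(C)c3ccccc23)n1` carries an unsubstituted pyridin-4-yl amide and in a functional assay on A549 cells (Homo sapiens) for antiproliferative activity, read by MTT assay, with a stated time of 72 h (a lower number here means a stronger inhibitor, a higher number a weaker inhibitor), compound 1 gives 4200 nM. Compound 2 `COc1cc(F)c(NC(=O)c2ccnc(Cl)c2)cc1Nc1nccc(-c2cn(C)c3ccccc23)n1` adds a chloro to that ring; in this assay compound 2 gives 6890 nM, the highest of the numbers shown, with compound 1 as its nearest neighbour. Going by the values given here, the step of a 1.6-fold higher number from compound 1 to compound 2 (0.21 log units; within the scatter) is the only measured step. Compound 3 `COc1cc(F)c(NC(=O)c2nccn2C)cc1Nc1nccc(-c2cn(C)c3ccccc23)n1` replaces the whole heteroaryl on the amide carbonyl: 1-methyl-1H-imidazol-2-yl in place of 2-chloropyridin-4-yl on a carbonyl carbon. Among the compounds with values here, the single measured step concerns a chloro on the same ring that now leaves entirely, so it bears only loosely on a ring exchange; no ring exchange has been measured here. With nothing pointing in either direction, the number for compound 3 is expected near that of compound 2, a step of a 1.3-fold lower number from compound 2 to compound 3 (0.10 log units; within the scatter) in this assay. Compound 3 is estimated at 5500 nM, within 1500 nM to 20000 nM.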

Compound 3, half-maximal inhibitory concentration: 5140 nM
Estimate against measurement, compound 3: 1.1-fold (0.03 log units) above; the range from low to high includes it.
By their numbers in this assay, from the lowest: compounds 1, 3 and 2 (each within the scatter of the next).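

In this assay the exchange of the six-membered 2-chloropyridin-4-yl for the five-membered 1-methyl-1H-imidazol-2-yl on the carbonyl carbon gives a 1.3-fold lower number from compound 2 to compound 3 (0.13 log units; within the scatter) and the same entering group set against pyridin-4-yl gives a 1.2-fold higher number from compound 1 to compound 3 (0.09 log units; within the scatter) so neither exchange moves the number beyond the scatter. A change of whole ring, in size and in hetero atom count, therefore reads no differently at this position from the chloro step, and compounds 1, 2 and 3 cannot be ordered. No data at hand offer an explanation for these closely spaced numbers.

Still open, from the compounds shown here alone, is whether any group on this carbonyl moves the number beyond the scatter. A saturated ring amine such as piperidine, or an aryl ring bearing a carboxylic acid, would test this.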